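Cytotoxicity notes on a thiazole sulfonamide series

The source may report more compounds than this note shows. Statements on the series, on what has been measured and on what is new or still open speak of the compounds shown alone.

Measured compounds in an ADME assay on HepG2 2.2.15 cells (Homo sapiens) for cytotoxicity; on this read-out lower numbers stand for higher toxicity in this test and higher numbers for lower toxicity in this test:
compound 1, `CC(C)(C)C(=O)Nc1ncc(C(Oc2ccc3cc(Br)ccc3c2)c2ccc(Cl)cc2)s1`: "not toxic" (no number reported)
compound 2, `O=C(Nc1ncc(C(Oc2ccc3cc(Br)ccc3c2)c2ccc(Cl)cc2)s1)c1ccc(F)cc1Br`: > 50000 nM, which is a limit of the assay and not a number
compound 3, `O=S(=O)(Nc1ncc(C(Oc2ccc3cc(Br)ccc3c2)c2ccc(Cl)cc2)s1)c1cccs1`: "not toxic" (no number reported)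

Compound 3 stands without a single number in this assay; its entry reads only as not toxic, next to one further entry without a number and one further value that is a limit. No order among the three can be drawn from this. The only quantified point in the set is the limit of > 50000 nM in this assay, at which 1 of the 3 values shown sits.

Compound 4, `Cc1ccc(S(=O)(=O)Nc2ncc(C(Oc3ccc4cc(Br)ccc4c3)c3ccc(Cl)cc3)s2)c2ccccc12`, differs from compound 3 by 4-methylnaphthalen-1-yl in place of thiophen-2-yl on a sulfonyl sulfur. Within the data shown here, no step between measured compounds is available to anchor the size of this change. Given that every measured entry shows no toxicity in this assay, no step beyond the usual scatter is expected in either direction for compound 4; a small shift toward higher toxicity cannot be excluded but is not expected to exceed the scatter. Compound 4 is therefore expected to give 50000 nM, estimated to lie between 15000 nM and 100000 nM, most likely reported again only as a limit.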

Compound 4, half-maximal cytotoxic concentration: > 50000 nM
Compound 4 gave a limit, no number (the forecaster's own chance of this, stated with the estimate: 60%); the middle value sits exactly at the limit.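

Among these compounds, compound 3 has no number and compound 4 gives only a limit of the assay, so no step between them can be read. The compounds shown leave open whether replacing thiophen-2-yl with 4-methylnaphthalen-1-yl changes the half-maximal cytotoxic concentration, as the only quantified point remains: the limit of > 50000 nM in this assay, at which 2 of the 4 values shown sit.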